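Trifluoromethyl for Fluoro on a Phenoxy Ring

The compounds below may be only part of what the source reports. "The series", "measured", "known", "first", "only" and "open" are said of these compounds alone.

compound 1 `Cc1cn(C2CCN(Cc3cncc(Oc4cccc(Cl)c4)c3)CC2)c(=O)[nH]c1=O`: > 64000 nM
compound 2 `Cc1cn(C2CCN(Cc3cccc(Oc4cccc(F)c4)c3)CC2)c(=O)[nH]c1=O`: > 64000 nM

Compound 1 and compound 2 share a core and differ only in the aryl ether part. In an ADME assay on MRC5 cells (Homo sapiens) for cytotoxicity, read by fluorescence and resazurin assay, with a stated time of 3 days (on this read-out lower numbers stand for stronger inhibition and higher numbers for weaker inhibition), compound 1 gives > 64000 nM, which is a limit of the assay and not a number. In this assay compound 2 gives > 64000 nM, likewise a limit and not a number. Both values sit at the limit of > 64000 nM in this assay, at which 2 of the 2 values shown sit, so compound 2 stands where compound 1 stands: neither shows cytotoxicity within the measured window.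

Compound 3 `Cc1cn(C2CCN(Cc3cccc(Oc4cccc(C(F)(F)F)c4)c3)CC2)c(=O)[nH]c1=O` carries trifluoromethyl in place of fluoro on an aromatic carbon relative to compound 2. Among the compounds with values here, no step between measured compounds is available to size this change, and the change itself is small. Compound 3 is therefore expected to remain at the limit, with a step from compound 2 of a step that the limit leaves unreadable from compound 2 to compound 3, none beyond the scatter. Compound 3 is estimated at 70000 nM, between 25000 nM and 200000 nM.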

Compound 3, half-maximal inhibitory concentration: 12400 nM
Estimate against measurement, compound 3: 5.6-fold (0.75 log units) above; measured number below the stated range.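

In this assay, trifluoromethyl in place of fluoro on an aromatic carbon, meta to a large group, gives an at least 5.1-fold lower number from compound 2 to compound 3 (0.71 log units; beyond the scatter), so a change at this position can bring the read-out off the limit. The earlier compounds could not show this, since both rest on that limit: the limit of > 64000 nM in this assay, at which 2 of the 3 values shown sit.

For compound 2, the value > 64000 nM is a limit of the assay and not a number, so the step gives only a smallest size, and the full size cannot be read.

The compounds shown leave open whether a methyl, a methoxy or a nitrile on the same aromatic carbon would also give a number below the limit. They also leave open whether trifluoromethyl in place of chloro on compound 1 would give a similar step.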